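The source may hold more compounds than are shown below. What is called first, only, known or untested is meant among the compounds shown, and "the series" means these compounds.

In an ADME assay for protein binding, using equilibrium dialysis, at pH 7.4, tested at 2 uM (on this read-out lower numbers stand for a smaller free fraction and higher numbers for a larger free fraction), compound 1 `CC(C)N(C(=O)C1CCC(F)(F)CC1)c1cc(C#CC(C)(C)C)sc1C(=O)O` gives 0.4, the higher of the two numbers available. Compound 3 `C[C@@H](CCOc1cccnc1)N(c1cc(C#CC(C)(C)C)sc1C(=O)O)C(=O)[C@H]1CC[C@H](C)CC1` gives 0.02, a much lower number, and that gap lies beyond the usual scatter. Compound 2 `CC(C)(C)C#Cc1cc(N(CCO)C(=O)[C@H]2CC[C@H](C)CC2)c(C(=O)O)s1` offers no comparison, since its entry reads "not determined" (no result reported). Compound 4 `CC(C)N(C(=O)C1CCCCCC1)c1cc(C#CC(C)(C)C)sc1C(=O)O` carries cycloheptyl in place of 4,4-difluorocyclohexyl on a carbonyl carbon, so the 4,4-difluorocyclohexyl leaves and a cycloheptyl, a seven-membered non-aromatic ring of carbon only, enters. Among the measured compounds shown here, no measured pair shows this change on its own, so any prediction here is only loosely grounded. The expected change, a 2.0-fold lower number from compound 1 to compound 4 (0.30 log units; within the scatter), is a modest fall in the number. For compound 4 the estimate is 0.2, with an expected range of 0.08 to 0.4.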

Compound 4, unbound fraction: 0.11
Compound 4: the middle estimate sits 1.8-fold (0.26 log units) above what was measured; the range from low to high includes it.
By their numbers in this assay, from the lowest: compound 3; then compound 4; then compound 1.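

Replacing 4,4-difluorocyclohexyl with cycloheptyl on this carbonyl carbon gives a 3.6-fold lower number from compound 1 to compound 4 (0.56 log units; beyond the scatter) in this assay, so this position alone can shift the free fraction by more than the scatter. The swap removes both fluorines and enlarges the ring in one step, and this single pair cannot separate those two differences. Nothing available explains the drop. A plain cyclohexyl at this position would help separate ring size from fluorine. From the compounds shown here alone, how a ring carrying an amine or a carboxylic acid would behave also remains open.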